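Methoxy to Chloro on the Acid-Bearing Ring

This account rests on a few compounds, and the source may have more. Where it says the series, first, only, none or still open, it means among the compounds named here.

Going by the values given here, compound 2 `COc1cc(C(=O)O)ccc1OCCCCOc1ccc(C(=O)CC(C)C)c(O)c1C` is the only compound here with a number: in an assay on HEK293 cells for positive allosteric modulation of metabotropic glutamate receptor 3 (Rattus norvegicus), read by thallium flux, with a stated time of 2.5 min (on this read-out higher numbers stand for an effect only at larger amounts of compound and lower numbers for an effect already at smaller amounts), compound 2 gives 614 nM. Compound 1 `COc1cc(C(=O)O)ccc1OCCCCOc1ccc(C(=O)C(C)C)c(O)c1C` shows "not determined" (no result reported) in this assay. Compound 3 `Cc1c(OCCCCOc2ccc(C(=O)O)cc2Cl)ccc(C(=O)CC(C)C)c1O` differs from compound 2 in one place: chloro in place of methoxy on an aromatic carbon. Among the compounds with values here, no measured pair of compounds shows what this change does in this assay, so the expected step of a 1.0-fold lower number from compound 2 to compound 3 (0.01 log units; within the scatter) is no larger than the usual scatter, in no firm direction. Compound 3 is therefore estimated at 600 nM in this assay, with a range from 200 nM to 2000 nM.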

Compound 3, half-maximal effective concentration: 1140 nM
For compound 3 the middle estimate is 1.9-fold (0.28 log units) below the measured one; the measured number falls inside the stated range.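

In this assay, chloro in place of methoxy on this aromatic carbon gives a 1.9-fold higher number from compound 2 to compound 3 (0.27 log units; within the scatter) and so leaves the read-out indistinguishable from that of compound 2. At this position, then, a single chlorine atom can stand in for the two heavy atoms of methoxy and the hydrogen-bond acceptor they bring, with no step beyond the usual scatter. Nothing available explains this result. This single pair cannot show how other groups here, such as a fluoro, a hydroxyl or an amine, would behave. It also leaves open whether the same swap gives a similar step on other compounds.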